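The compounds below may be only part of what the source reports. "The series", "measured", "known", "first", "only" and "open" are said of these compounds alone.

Among the compounds with values here, in a functional assay on MC-38 cells (Mus musculus) for antiproliferative activity, read by CCK-8 assay, with a stated time of 48 h (on this read-out higher numbers stand for weaker inhibition and lower numbers for stronger inhibition), compound 2 `COc1ccc(/C=C\c2cc(OC)c(OC)c(OC)c2)cc1OCc1ccc(CNCCN(C)C)cc1` gives 1400 nM, the only exact number so far. Compound 1 `COc1ccc(/C=C\c2cc(OC)c(OC)c(OC)c2)cc1OCc1ccc(CN[C@H](C(=O)O)[C@H](C)O)cc1` is reported only as a limit, > 10000 nM. Compound 3 `COc1ccc(/C=C\c2cc(OC)c(OC)c(OC)c2)cc1OCc1ccc(CN2CC[C@@H](C(=O)O)C2)cc1` carries 3-carboxypyrrolidin-1-yl in place of (2-(dimethylamino)ethyl)amino on a saturated chain carbon bound to an aromatic carbon. Within the data shown here, one measured step bears on this change, an at least 7.1-fold lower number from compound 1 to compound 2 (0.85 log units; beyond the scatter), where 2-(dimethylamino)ethyl replaced the carboxy-bearing 1-carboxy-2-hydroxypropyl. Compound 3 brings a carboxy group back, so that step is expected to run partly in reverse, as an estimated rise a 5.0-fold higher number from compound 2 to compound 3 (0.70 log units; beyond the scatter). The expected value for compound 3 is 7000 nM, with an estimated range of 2000 nM to 25000 nM.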

Compound 3, half-maximal inhibitory concentration: 6300 nM
For compound 3 the middle estimate is 1.1-fold (0.05 log units) above the measured one; measured number inside the range.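

In this assay, the swap to 3-carboxypyrrolidin-1-yl gives a weaker compound (a 4.5-fold higher number from compound 2 to compound 3 (0.65 log units; beyond the scatter)), so both carboxy-bearing groups at this place now fall on the weaker side of the 2-(dimethylamino)ethyl chain. Compared with the open-chain carboxy group, the ring gives only a floor (an at least 1.5-fold lower number from compound 1 to compound 3 (0.20 log units; that floor lies within the scatter)), which cannot rank the two, as compound 1 is reported only as a limit of the assay: the limit of > 10000 nM in this assay, at which 1 of the 3 values shown sits.

On these data alone, compound 3 brings in the ring and the carboxy group together, so their separate contributions remain open. Also open, as far as these compounds go, is how a pyrrolidin-1-yl without the carboxylic acid, or a primary amine, would compare here.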